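Cytotoxicity in HeLa Cells: from Compound 1 to Compound 4

This account rests on a few compounds, and the source may have more. Where it says the series, first, only, none or still open, it means among the compounds named here.

Compound 1 `CCOC(=O)c1cc(CCCOc2ccc(-c3noc(C(F)(F)F)n3)cc2)on1` carries an ethyl ester on the shared core. In an ADME assay on HeLa cells (Homo sapiens) for cytotoxicity, read by crystal violet staining, with a stated time of 72 h (a lower number here means that less compound is tolerated, a higher number that more compound is tolerated), compound 1 gives only a limit, > 100000 nM, and no number (the limit of > 100000 nM in this assay, at which 1 of the 3 values shown sits). Compound 3 `CN(C)C(=O)c1cc(CCCOc2ccc(-c3noc(C(F)(F)F)n3)cc2)on1` differs by one change, dimethylamino in place of ethoxy on a carbonyl carbon, and in this assay compound 3 gives 28000 nM; the step is an at least 3.5-fold lower number from compound 1 to compound 3 (0.55 log units; beyond the scatter). Compound 2 `Cc1cc(-c2noc(C(F)(F)F)n2)cc(C)c1OCCCc1cc(C(=O)OC(C)C)no1` differs from compound 1 in more than one place, and in this assay compound 2 gives 17900 nM. Compound 4 `CCOC(=O)c1cc(CCCOc2ccc(-c3noc(C(F)(F)F)n3)cc2/N=C/N(C)C)on1` differs from compound 1 by a group of 5 heavy atoms (3 carbon, 2 nitrogen; no ring) in place of a hydrogen atom, on an aromatic carbon. Among the compounds with values here, no measured step changes the aromatic ring in this way, so the step from compound 1 to compound 3 bears on it only loosely. The expectation is a modest move to a lower number, an at least 2.0-fold lower number from compound 1 to compound 4 (0.30 log units; that floor lies within the scatter), and compound 4 is estimated at 50000 nM, with a range from 15000 nM to 100000 nM.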

Compound 4, half-maximal cytotoxic concentration: > 100000 nM
Compound 4 ended at the assay's limit (the forecaster's own chance of this, stated with the estimate: 40%); middle value at least 2.0-fold (0.30 log units) away from the limit.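

In this assay compound 4 gives > 100000 nM, which is a limit, and compound 1 also stands at a limit, so the step between compound 1 and compound 4 cannot be read: the limit of > 100000 nM in this assay, at which 2 of the 4 values shown sit. The compounds shown leave open whether the group added in compound 4 shifts the tolerated concentration at all.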